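The source may hold more compounds than are shown below. What is called first, only, known or untested is meant among the compounds shown, and "the series" means these compounds.

Compound 1 `CC(C)(C)c1ccc(C(=O)NC(=O)c2ccccc2O)cc1` gives 2.3 ug/mL. Compound 2 `CCOc1ccc(C(=O)NC(=O)c2ccccc2O)cc1` gives 17 ug/mL.

In an ADME assay on L6 cells (Rattus norvegicus) for cytotoxicity, read by resazurin assay, with a stated time of 72 h (a lower number here means a stronger inhibitor, a higher number a weaker inhibitor), compound 1 has the lowest of the two numbers. Compound 3 `COC(=O)CCC(=O)Nc1ccc(C(=O)NC(=O)c2ccccc2O)cc1` is reached from compound 1 by one change: ((2-(methoxycarbonyl)ethyl)carbonyl)amino in place of tert-butyl on an aromatic carbon. Going by the values given here, the one measured step that bears on it is a 7.4-fold higher number from compound 1 to compound 2 (0.87 log units; beyond the scatter), which was beyond the scatter and upward when the tert-butyl was exchanged. A step of at least that size, upward, is therefore expected for compound 3, namely a 13-fold higher number from compound 1 to compound 3 (1.12 log units; beyond the scatter). Compound 3 is expected to give 30 ug/mL, with a likely range from 8 ug/mL to 100 ug/mL.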

Compound 3, half-maximal inhibitory concentration: > 50 ug/mL
Compound 3: a limit, no number; the forecaster's own chance of this, stated with the estimate: 20%; at least 1.6-fold (0.22 log units) between middle value and limit.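

In this assay compound 3 gives a limit and not a number: the limit of > 50 ug/mL in this assay, at which 1 of the 3 values shown sits. At this aromatic carbon, ((2-(methoxycarbonyl)ethyl)carbonyl)amino in place of tert-butyl gives an at least 21-fold higher number from compound 1 to compound 3 (1.33 log units; beyond the scatter), and in place of ethoxy it gives an at least 2.9-fold higher number from compound 2 to compound 3 (0.46 log units; beyond the scatter). The position therefore tolerates a further rise beyond the one that ethoxy showed, and the number moves upward from both earlier groups.

Going by these compounds, how far compound 3 lies past its limit stays open. Also open, on these data alone, is whether a shorter acetylamino group or a free carboxylic acid at the end of the chain would give a readable number.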